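A few compounds are considered here, and "the series" means these few. Any claim that something is new, unique, unknown or untested is made for them only; others in the source may bear on it.

Compound 1 `CC(=O)N(C)C(C)C#CCn1cncc1C`: 80 mg/kg
Compound 2 `CC(=O)NCC#CCn1cncc1C`: > 100 mg/kg, a limit
Compound 3 `CC(=O)N(C)CC#CCn1cncc1C`: > 100 mg/kg, a limit

All three compounds were tested in a functional assay on the whole organism for antagonist activity, with Mus musculus as the target; a lower number here means that less compound is needed, a higher number that more compound is needed for the effect. Compound 3 sits at the limit of > 100 mg/kg in this assay, at which 2 of the 3 values shown sit, so it has a limit and no exact number. Compound 4 `COC(=O)NCC#CCn1cncc1C` has not yet been measured, and it differs from compound 3 as follows: (methoxycarbonyl)amino in place of acetyl(methyl)amino on a saturated chain carbon bound to a triple-bonded carbon. Compound 4 has no methyl on the amide-type nitrogen, so the closest guide is a step that the two limits leave unreadable from compound 2 to compound 3. The other measured step, an at least 1.2-fold higher number from compound 1 to compound 3 (0.09 log units; that floor lies within the scatter), concerns a different place and gives no readable size either. No change beyond the scatter is therefore expected, and the estimated step is a step that the limit leaves unreadable from compound 3 to compound 4. For compound 4 the expected value is 120 mg/kg, with an estimated range of 70 mg/kg to 250 mg/kg.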

Compound 4, dose for half-maximal effect: > 100 mg/kg
Compound 4: no number, only a limit; the forecaster's own chance of this, stated with the estimate: 75%; the middle value does not contradict the limit.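

In this assay, compound 2, compound 3 and compound 4 each give only a limit, so no step among them can be read: the limit of > 100 mg/kg in this assay, at which 3 of the 4 values shown sit.

The compounds shown leave open what their actual doses are, and whether (methoxycarbonyl)amino in place of acetyl(methyl)amino changes the dose at all.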